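The source may hold more compounds than are shown below. What is called first, only, known or untested is meant among the compounds shown, and "the series" means these compounds.

Values in a functional assay on SW480 cells (Homo sapiens) for inhibition, read by luminescence and resazurin assay, with a stated time of 3 days; a lower number here means a stronger inhibitor, a higher number a weaker inhibitor:
- compound 1 `Cc1ccc(S(=O)(=O)Nc2ccc(CNc3nc(N(C)C)nc4ccccc34)cc2)cc1`: 13000 nM
- compound 2 `CN(C)c1nc(NCc2ccc(NC(=O)c3ccncc3)cc2)c2ccccc2n1`: 11000 nM
- compound 3 `CN1CCN(c2nc(NCc3ccc(NC(=O)c4ccncc4)cc3)c3ccccc3n2)CC1`: > 20000 nM, a limit of the assay

The two numeric values lie close together, with a 1.2-fold lower number from compound 1 to compound 2 (0.07 log units; within the scatter). Compound 3 gives only a limit, > 20000 nM.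

Compound 4 `CNc1nc(NCc2ccc(NS(=O)(=O)c3ccc(C)cc3)cc2)c2ccccc2n1` is the next entry, and it derives from compound 1 by a single change: hydrogen in place of methyl on a nitrogen on an aromatic ring. This is hydrogen in place of methyl on a nitrogen on an aromatic ring, which turns dimethylamino into methylamino.

For the measured compounds named here, no measured step makes this exact change. The nearest is the replacement of the dimethylamino group, an at least 1.8-fold higher number from compound 2 to compound 3 (0.25 log units; that floor lies within the scatter), and its floor lies within the scatter. The change on the other side of the molecule, a 1.2-fold lower number from compound 1 to compound 2 (0.07 log units; within the scatter), sits elsewhere and is also within the scatter. No step beyond the scatter is therefore expected in this assay.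

The estimated step is a 1.1-fold lower number from compound 1 to compound 4 (0.03 log units; within the scatter).

For compound 4 the expected value is 12000 nM, with an estimated range of 5000 nM to 20000 nM.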

Compound 4, half-maximal inhibitory concentration: 4900 nM
Beside the measured number, compound 4's estimate is 2.4-fold (0.39 log units) above it, and the stated range ends above it.
By their numbers in this assay, from the lowest: compound 4; then compounds 2 and 1 (each within the scatter of the next). At a limit, above all of these: compound 3.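

In this assay, for the compounds shown here, the change from dimethylamino to methylamino gives a 2.7-fold lower number from compound 1 to compound 4 (0.42 log units; beyond the scatter), the first step printed as beyond the scatter. A single methyl on this nitrogen therefore shifts the number, modestly, whereas the exchange of (4-methylphenyl)sulfonyl for (pyridin-4-yl)carbonyl elsewhere on the molecule stayed within the scatter. Compound 3, the one other change at this aromatic carbon, gives only a limit, so that earlier change has no measured size: the limit of > 20000 nM in this assay, at which 1 of the 4 values shown sits.

Going by these compounds, whether the step carries over to the (pyridin-4-yl)carbonyl side of the series remains open, as does the effect of an unsubstituted amino group or an ethylamino group at this place. What the removed methyl does in these cells cannot be told from these values.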